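From 3-chlorophenyl to 4-cyanophenyl on the amide nitrogen

This account rests on a few compounds, and the source may have more. Where it says the series, first, only, none or still open, it means among the compounds named here.

- Compound 1 `CCCc1ccc(NC(=O)C2CCN(C/C=C/c3ccccc3)CC2)cc1`: 5210 nM
- Compound 2 `CCCCc1ccc(NC(=O)C2CCN(C/C=C/c3ccccc3)CC2)cc1`: 2570 nM
- Compound 3 `O=C(Nc1cccc(Cl)c1)C1CCN(C/C=C/c2ccccc2)CC1`: 11300 nM

These values come from a functional assay on MGC-803 cells (Homo sapiens) for inhibition, read by MTT assay, with a stated time of 72 h; a higher number here means a weaker inhibitor, a lower number a stronger inhibitor. Compound 3 stands highest of the three and is thus the weakest inhibitor, with compound 1 nearest and compound 2 furthest. Compound 4 `N#Cc1ccc(NC(=O)C2CCN(C/C=C/c3ccccc3)CC2)cc1` carries 4-cyanophenyl in place of 3-chlorophenyl on an amide-type nitrogen. The closest evidence is a 2.2-fold higher number from compound 1 to compound 3 (0.34 log units; beyond the scatter), a modest step at that same nitrogen. The other step, a 2.0-fold lower number from compound 1 to compound 2 (0.31 log units; beyond the scatter), is equally modest and concerns only a chain. For the measured compounds named here, no measured compound carries a nitrile, so no step beyond the scatter is expected in this assay, in either direction. The expected outcome is a 1.1-fold lower number from compound 3 to compound 4 (0.05 log units; within the scatter). For compound 4 the estimate is 10000 nM, with an expected range of 4500 nM to 25000 nM.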

Compound 4, half-maximal inhibitory concentration: 28200 nM
The estimate for compound 4 lay 2.8-fold (0.45 log units) below the measured number, outside the stated range (above it).
By their numbers in this assay, from the lowest: compound 2; then compound 1; then compound 3; then compound 4.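

In this assay, replacing the group on the amide-type nitrogen with 4-cyanophenyl gives a 2.5-fold higher number from compound 3 to compound 4 (0.40 log units; beyond the scatter), making compound 4 the weakest inhibitor of the four. Cyano in place of the alkyl chains gives a 5.4-fold higher number from compound 1 to compound 4 (0.73 log units; beyond the scatter) and an 11-fold higher number from compound 2 to compound 4 (1.04 log units; beyond the scatter), the latter the only large step so far. Nothing measured here accounts for these rises. From the compounds shown here alone, it remains open whether they follow the nitrile itself or its place on the ring, which 4-chlorophenyl would help to separate. Going by these compounds, whether a pentyl chain would continue the lower numbers also remains open.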